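The compounds below may be only part of what the source reports. "The series", "measured", "known", "first", "only" and "open" are said of these compounds alone.

The account follows the step from compound 1 `Cc1ccc(NC(=O)c2ccc3cccc(O)c3n2)cc1` to compound 4 `O=C(Nc1ccc([N+](=O)[O-])cc1)c1ccc2cccc(O)c2n1`. In an ADME assay on THP-1 cells (Homo sapiens) for cytotoxicity, read by WST assay, with a stated time of 24 h (a higher number here means a weaker inhibitor, a lower number a stronger inhibitor), compound 1 gives > 30000 nM, which is a limit of the assay rather than a number. Compound 2 `O=C(Nc1cccc(Cl)c1)c1ccc2cccc(O)c2n1` gives > 30000 nM in this assay, again a limit. Compound 3 `O=C(Nc1cccc(Br)c1)c1ccc2cccc(O)c2n1` gives > 30000 nM in this assay, likewise a limit. Compound 1 therefore stands at the limit together with the two others, as shown by the limit of > 30000 nM in this assay, at which 3 of the 3 values shown sit. The change from compound 1 to compound 4 is nitro in place of methyl on an aromatic carbon. Of the measured steps, a step that the two limits leave unreadable from compound 1 to compound 2 and a step that the two limits leave unreadable from compound 1 to compound 3 start from compound 1 and replace the group on the amide-type nitrogen, while a step that the two limits leave unreadable from compound 2 to compound 3 puts bromo in place of chloro on an aromatic carbon. All three are unreadable because every value involved sits at the limit described by the limit of > 30000 nM in this assay, at which 3 of the 3 values shown sit. Among the compounds with values here, no step in this set gives a direction or a size, so compound 4 is expected to remain at the limit, and a step that the limit leaves unreadable from compound 1 to compound 4 is expected to be no step readable beyond the scatter. Compound 4 is estimated at 40000 nM, between 20000 nM and 100000 nM.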

Compound 4, half-maximal inhibitory concentration: > 30000 nM
Compound 4: only a limit was reported; the forecaster's own chance of this, stated with the estimate: 85%; the middle value lies beyond the limit too.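

The step from compound 1 to compound 4 cannot be read, since both compounds sit at a limit of the assay: the limit of > 30000 nM in this assay, at which 4 of the 4 values shown sit. The compounds shown leave open how far any of them lies beyond that limit in this assay, and so which changes matter.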